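Removing a Methoxy Group from Compound 3

The source may hold more compounds than are shown below. What is called first, only, known or untested is meant among the compounds shown, and "the series" means these compounds.

Compound 1 `O=C1C(=Cc2ccc(O)cc2)C(=O)N(c2ccc(Cl)cc2)N1c1ccc(Cl)cc1` gives 20600 nM in a functional assay on SMMC-7721 cells (Homo sapiens) for cytotoxicity, read by MTT assay, with a stated time of 72 h; on this read-out higher numbers stand for weaker inhibition and lower numbers for stronger inhibition.
Compound 2 `COc1cc(C=C2C(=O)N(c3ccc(Cl)cc3)N(c3ccc(Cl)cc3)C2=O)ccc1O` gives 64900 nM in this assay.
Compound 3 `COc1cccc(C=C2C(=O)N(c3ccc(Cl)cc3)N(c3ccc(Cl)cc3)C2=O)c1OC` gives 14100 nM in this assay.

All three compounds share one core and differ only in the aryl group hanging from it. Compound 3 carries the lowest number of the three; its gap to compound 1, a 1.5-fold lower number from compound 1 to compound 3 (0.16 log units; within the scatter), is within the scatter, while its gap to compound 2, a 4.6-fold lower number from compound 2 to compound 3 (0.66 log units; beyond the scatter), is beyond it. The difference between compound 2 and compound 3 is 2,3-dimethoxyphenyl in place of 4-hydroxy-3-methoxyphenyl on a double-bonded chain carbon bound to a double-bonded ring carbon.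

Compound 4 `COc1ccccc1C=C1C(=O)N(c2ccc(Cl)cc2)N(c2ccc(Cl)cc2)C1=O` has not yet been measured in this assay. It differs from compound 3 by hydrogen in place of methoxy on an aromatic carbon. The same kind of change has already been made once, from compound 2 to compound 1: hydrogen in place of methoxy on an aromatic carbon, and there it gave a 3.2-fold lower number from compound 2 to compound 1 (0.50 log units; beyond the scatter). The two places are not identical: in compound 2 the leaving methoxy sits ortho to a hydroxy group, whereas in compound 3 it sits ortho to a methoxy group; both are meta to a large group.

Because a 3.2-fold lower number from compound 2 to compound 1 (0.50 log units; beyond the scatter) was a modest improvement, a step of similar direction but uncertain size is expected from compound 3 to compound 4, estimated at a 1.6-fold lower number from compound 3 to compound 4 (0.19 log units; within the scatter). Compound 4 is therefore expected to give about 9000 nM, with a plausible range from 3500 nM to 25000 nM; this rests on a single earlier example at a differently substituted ring.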

Compound 4, half-maximal inhibitory concentration: 25800 nM
Beside the measured number, compound 4's estimate is 2.9-fold (0.46 log units) below it; measured number above the stated range.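

Hydrogen in place of methoxy on an aromatic carbon does not carry over as a fixed effect between these two aryl settings in this assay, and the earlier gain does not reappear: the same change on two cores in this assay, a 3.2-fold lower number (0.50 log units; beyond the scatter) from compound 2 to compound 1 and a 1.8-fold higher number (0.26 log units; within the scatter) from compound 3 to compound 4, 5.8-fold (0.76 log units) apart, beyond the scatter of two such steps. Taken alone, the new step, a 1.8-fold higher number from compound 3 to compound 4 (0.26 log units; within the scatter), is too small to count as a real loss, so going from 2,3-dimethoxyphenyl to 2-methoxyphenyl shows no clear change in either direction. The other two steps place compound 4 among its neighbours, with a 2.5-fold lower number from compound 2 to compound 4 (0.40 log units; beyond the scatter) and a 1.3-fold higher number from compound 1 to compound 4 (0.10 log units; within the scatter), but these two examples of the change show only that its outcome depends on the surroundings, not which feature of those surroundings decides it, and they give no rule for other aryl groups in the series.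

The compounds shown leave open whether the hydroxy group shared by compound 1 and compound 2 is what separates the two outcomes, a question that a matched pair carrying a different group in its place, such as an amine or a carboxylic acid, could test. They also leave open how a fluorine or a longer chain such as ethoxy would behave at the place of the leaving methoxy.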